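Ethoxy in Place of Nitro on the Aromatic Ring

The compounds below may be only part of what the source reports. "The series", "measured", "known", "first", "only" and "open" are said of these compounds alone.

Compound 1 `COc1cc(N)c(Cl)cc1NC(=O)C1CCN(CC2CCCCC2)CC1`: 2.9 mg/kg
Compound 2 `COc1cc(N)c(Cl)cc1NC(=O)C1CCN(Cc2ccc([N+](=O)[O-])cc2)CC1`: > 4 mg/kg, a limit of the assay
Compound 3 `COc1cc(N)c(Cl)cc1NC(=O)C1CCN(C2CCCC2)CC1`: > 10 mg/kg, a limit of the assay

In a functional assay on the whole organism for antagonist activity, with Mus musculus as the target (a higher number here means that more compound is needed for the effect, a lower number that less compound is needed), compound 2 sits at the limit of > 4 mg/kg in this assay, at which 1 of the 3 values shown sits, so only a bound and no number is known for it. Compound 4 `CCOc1ccc(CN2CCC(C(=O)Nc3cc(Cl)c(N)cc3OC)CC2)cc1` differs from compound 2 by ethoxy in place of nitro on an aromatic carbon. Among the measured compounds shown here, no measured step touches this part of the molecule: an at least 1.3-fold higher number from compound 1 to compound 2 (0.13 log units; that floor lies within the scatter) and an at least 3.4-fold higher number from compound 1 to compound 3 (0.53 log units; beyond the scatter) both alter the group on the ring nitrogen, not the nitro. With compound 2 itself a limit, the direction of the step cannot be read from the data, and no change beyond the scatter is expected. Compound 4 is estimated at 5 mg/kg, in the range 1.5 mg/kg to 15 mg/kg, which is expected to mean a step that the limit leaves unreadable from compound 2 to compound 4.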

Compound 4, dose for half-maximal effect: 6.3 mg/kg
The estimate for compound 4 lay 1.3-fold (0.10 log units) below the measured number, and the stated range covers the measured number.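

With 4-ethoxyphenyl, this assay gives an actual number for a substituted phenyl group on this chain carbon, not just a limit. Replacing cyclohexyl with this group gives a 2.2-fold higher number from compound 1 to compound 4 (0.34 log units; beyond the scatter), so the phenyl compound needs more compound for the effect but still reaches it. Whether ethoxy differs from nitro cannot be read, because compound 2 has only a limit: the limit of > 4 mg/kg in this assay, at which 1 of the 4 values shown sits.

Going by these compounds, it remains open how much the group at this position matters. An amine or a longer ether chain in place of ethoxy could show that.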